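Dropping the aryl methyl: compound 1 to compound 4

The source may report more compounds than this note shows. Statements on the series, on what has been measured and on what is new or still open speak of the compounds shown alone.

Of the compounds shown here, three have been measured in an assay on isolated protein for displacement of a labelled ligand from Apoptosis regulator Bcl-2 (Homo sapiens), read by fluorescence polarization; a higher number here means a weaker inhibitor, a lower number a stronger inhibitor. Compound 1 `Cc1cc(S(=O)(=O)NC(=O)c2ccc(N3CCN(Cc4ccccc4-c4ccc(Cl)cc4)CC3)cc2)ccc1N[C@H](CCN(C)C)CSc1ccccc1` returns only a limit in this assay, < 1 nM, not a number. Compound 2 `CN(C)CC[C@H](CSc1ccccc1)Nc1ccc(S(=O)(=O)NC(=O)c2ccc(N3CCN(CC4=C(c5ccc(Cl)cc5)CCC4)CC3)cc2)cc1[N+](=O)[O-]` likewise sits at the limit of this assay with < 1 nM. Compound 3 `CN(C)CC[C@H](CSc1ccccc1)Nc1ccc(S(=O)(=O)NC(=O)c2ccc(N3CCN(CC4=C(c5ccc(Cl)cc5)CCCCC4)CC3)cc2)cc1[N+](=O)[O-]` also gives the limit, < 1 nM. Among the measured compounds shown here, no step between measured compounds can be stated, since every value is a limit; the one thing the numbers show is the limit of < 1 nM in this assay, at which 3 of the 3 values shown sit, so compound 1 cannot be placed above or below its two neighbours, and none of the three can be called the strongest.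

Compound 4 `CN(C)CC[C@H](CSc1ccccc1)Nc1ccc(S(=O)(=O)NC(=O)c2ccc(N3CCN(Cc4ccccc4-c4ccc(Cl)cc4)CC3)cc2)cc1` is to be measured in this assay. Compared with compound 1 the change is hydrogen in place of methyl on an aromatic carbon, ortho to a large group and meta to a large group. For the measured compounds named here, no measured step of this kind exists, and nothing among the measurements speaks to it. A change of one carbon with no ring, donor, acceptor or charge involved is expected to move the result little, in either direction, not beyond the scatter. The expected step on the numbers is a step that the limit leaves unreadable from compound 1 to compound 4. For compound 4 the estimate is 0.8 nM, with a range from 0.2 nM to 3 nM, and most likely the assay will again report only its limit.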

Compound 4, inhibition constant: < 1 nM
Compound 4: only a limit was reported; the forecaster's own chance of this, stated with the estimate: 65%; the middle value does not contradict the limit.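

In this assay compound 4 gives < 1 nM, a limit and not a number. Compound 1 also returns only a limit, so no step can be read between compound 1 and compound 4: the limit of < 1 nM in this assay, at which 4 of the 4 values shown sit. The compounds shown leave open what hydrogen in place of methyl on an aromatic carbon does to the inhibition constant, and how the four compounds rank.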